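The compounds below may be only part of what the source reports. "The series", "measured", "known", "first", "only" and "open" are said of these compounds alone.

Measured so far in a functional assay on SGC-7901 cells (Homo sapiens) for cytotoxicity, read by MTT assay, with a stated time of 48 h (on this read-out higher numbers stand for weaker inhibition and lower numbers for stronger inhibition), as follows:
compound 1 `O=C(CSc1ccc(Br)cc1)N1N=C(c2cc3ccccc3oc2=O)C[C@@H]1c1ccc(C(F)(F)F)cc1` gives 12100 nM
compound 2 `O=C(CSCc1ccco1)N1N=C(c2cc3ccccc3oc2=O)C[C@@H]1c1ccc(C(F)(F)F)cc1` gives 9740 nM
compound 3 `O=C(CSc1ccc([N+](=O)[O-])cc1)N1N=C(c2cc3ccccc3oc2=O)C[C@@H]1c1ccc(C(F)(F)F)cc1` gives 8510 nM

On these numbers compound 3 cannot be told apart from the other two. The closest comparison is a 1.1-fold lower number from compound 2 to compound 3 (0.06 log units; within the scatter) and the widest is a 1.4-fold lower number from compound 1 to compound 3 (0.15 log units; within the scatter) so the three values form a single group.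

The next molecule is compound 4 `CCCCSCC(=O)N1N=C(c2cc3ccccc3oc2=O)C[C@@H]1c1ccc(C(F)(F)F)cc1` which has not yet been measured. It carries butyl in place of 4-nitrophenyl on a sulfur and the rest of the structure stays the same.

All three measured steps bear on this change. Going by the values given here, exchanging the group on that sulfur gave a 1.2-fold lower number from compound 1 to compound 2 (0.09 log units; within the scatter) and also a 1.1-fold lower number from compound 2 to compound 3 (0.06 log units; within the scatter) while the remaining step was the one already given for compound 1 and compound 3. As far as these compounds go, none of these steps left the scatter, yet every measured compound has a ring in this group, so an open chain is untested here. For that reason, only a small move is expected in this assay and the direction is uncertain.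

The expected change is a 1.2-fold higher number from compound 3 to compound 4 (0.07 log units; within the scatter) and this estimate stays within the usual scatter.

For compound 4 the estimated value is 10000 nM with an expected range from 5000 nM to 20000 nM around it.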

Compound 4, half-maximal inhibitory concentration: 2910 nM
Beside the measured number, compound 4's estimate is 3.4-fold (0.54 log units) above it, and the stated range ends above it.
By their numbers in this assay, from the lowest: compound 4; then compounds 3, 2 and 1 (each within the scatter of the next).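

In this assay the group on the sulfur proves able to shift the result: butyl, an open chain with no ring, gives a 2.9-fold lower number from compound 3 to compound 4 (0.47 log units; beyond the scatter) and a 4.2-fold lower number from compound 1 to compound 4 (0.62 log units; beyond the scatter) in place of the two aryl groups. The comparison with the (furan-2-yl)methyl group points the same way, with a 3.3-fold lower number from compound 2 to compound 4 (0.52 log units; beyond the scatter) and so, with all three steps beyond the scatter, compound 4 is the most potent of the four, whereas compounds 1, 2 and 3, which all carry a ring in this group, remain within the scatter of one another. Nothing shown here accounts for this difference.

With only one open chain among these compounds, it remains unknown whether chain length itself matters, which a shorter ethyl group, a longer hexyl group or a branched isopropyl group on the same sulfur could help to answer. As far as these compounds go, it is also open whether the gain would survive in a chain carrying an amine or a carboxylic acid.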